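The compounds below may be only part of what the source reports. "The series", "measured", "known", "first", "only" and "open" are said of these compounds alone.

Compound 1 `CCC1=C(O)c2c(oc(-c3ccc(C(C)C)cc3)cc2=O)C(CC)(CC)C1=O`: 8.13 uM
Compound 2 `CCOc1ccc(-c2cc(=O)c3c(o2)C(CC)(CC)C(=O)C(CC)=C3O)cc1`: only a limit, > 52.4 uM

In a functional assay on KB cells (Homo sapiens) for antiproliferative activity, read by sulforhodamine B assay, with a stated time of 3 days (a higher number here means that more compound is needed for the effect, a lower number that less compound is needed), compound 1 gives 8.13 uM. Among the two values shown, compound 1 holds the only real number; the other is a limit of the assay. Compound 2 reaches only that limit, > 52.4 uM, so no number is known for it. For the measured compounds named here, the single measured step is an at least 6.4-fold higher number from compound 1 to compound 2 (0.80 log units; beyond the scatter), and it runs up to the limit of > 52.4 uM in this assay, at which 1 of the 2 values shown sits, so its true size is known only as a minimum.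

Compound 3 `CCC1=C(O)c2c(oc(-c3ccc(OC)c(F)c3)cc2=O)C(CC)(CC)C1=O` differs from compound 1 in one place: 3-fluoro-4-methoxyphenyl in place of 4-isopropylphenyl on an aromatic carbon. Like the change from compound 1 to compound 2, this removes the isopropyl group from the aromatic ring and puts in a group carrying oxygen, so the step of an at least 6.4-fold higher number from compound 1 to compound 2 (0.80 log units; beyond the scatter) is the only guide, and it points toward a higher number, possibly again beyond the limit.

Compound 3 is therefore expected to give about 40 uM, between 10 uM and 110 uM. That estimate for compound 3 means an expected step of a 4.9-fold higher number from compound 1 to compound 3 (0.69 log units; beyond the scatter).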

Compound 3, concentration for half-maximal effect: 26.7 uM
Estimate against measurement, compound 3: 1.5-fold (0.18 log units) above, and the stated range covers the measured number.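

In this assay, the change to 3-fluoro-4-methoxyphenyl gives a 3.3-fold higher number from compound 1 to compound 3 (0.52 log units; beyond the scatter), which puts a true size on replacing 4-isopropylphenyl at this position with a ring carrying oxygen, where the earlier step gave only a minimum. This shows that a ring with an oxygen-linked group at this position can still give a measurable number in this assay, even though compound 1 keeps the lowest number of the three compounds and neither replacement improves on it. The remaining comparison gives an at least 1.9-fold lower number from compound 2 to compound 3 (0.29 log units; that floor lies within the scatter), so no order can be claimed between those two compounds, since one end of the step is only a limit: the limit of > 52.4 uM in this assay, at which 1 of the 3 values shown sits.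

The compounds shown do not separate the contribution of the fluorine from that of the methoxy group, since these two changes arrive together in compound 3, and a 3-fluorophenyl or 4-methoxyphenyl group would be needed to pull them apart. They also leave open how the shared core would respond to a 4-tert-butylphenyl group, which keeps an all-carbon branched chain, or to a ring bearing an amine or a carboxylic acid.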